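The source may report more compounds than this note shows. Statements on the series, on what has been measured and on what is new or still open speak of the compounds shown alone.

Three compounds that share the core of compound 1 `CC(C)=CCOc1cc(Nc2ncccn2)ccc1Cl` have been tested in a functional assay on MT2 cells (Homo sapiens) for cytotoxicity; on this read-out higher numbers stand for lower toxicity in this test and lower numbers for higher toxicity in this test. Compound 1 gives 2500 nM. Compound 2 `CC(C)=CCOc1cc(Nc2nccc(N)n2)ccc1Cl`, which carries an amino group in place of a ring hydrogen, gives 500 nM in this assay, so that the step of a 5.0-fold lower number from compound 1 to compound 2 (0.70 log units; beyond the scatter) is beyond the scatter. Compound 3 `CC(C)=CCOc1cc(Nc2nccc(C(F)(F)F)n2)ccc1Cl` gives 2500 nM in this assay; the step of no change at the digits printed from compound 1 to compound 3 (within the scatter) leaves it level with compound 1, and the two together stand highest of the three, while the step of a 5.0-fold higher number from compound 2 to compound 3 (0.70 log units; beyond the scatter) separates compound 3 from compound 2.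

Compound 4 `CSc1ccnc(Nc2ccc(Cl)c(OCC=C(C)C)c2)n1` has not yet been measured. It differs from compound 3 in one place.

methylsulfanyl in place of trifluoromethyl on an aromatic carbon

For the measured compounds named here, two measured steps touch this same aromatic carbon: no change at the digits printed from compound 1 to compound 3 (within the scatter) and a 5.0-fold higher number from compound 2 to compound 3 (0.70 log units; beyond the scatter). Hydrogen and trifluoromethyl at this carbon gave numbers within the scatter of each other; only the amino group gave a lower number. Methylsulfanyl is neither of these, and no measured step involves it, so the expected step is small: a 1.3-fold lower number from compound 3 to compound 4 (0.10 log units; within the scatter). Compound 4 is estimated at 2000 nM, with a range from 600 nM to 5000 nM.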

Compound 4, half-maximal cytotoxic concentration: 2800 nM
Estimate against measurement, compound 4: 1.4-fold (0.15 log units) below; measured number inside the range.
By their numbers in this assay, from the lowest: compound 2; then compounds 1, 3 and 4 (each within the scatter of the next).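

In this assay, methylsulfanyl at this aromatic carbon falls with trifluoromethyl and hydrogen: putting it in place of trifluoromethyl gives a 1.1-fold higher number from compound 3 to compound 4 (0.05 log units; within the scatter), and putting it in place of hydrogen gives a 1.1-fold higher number from compound 1 to compound 4 (0.05 log units; within the scatter). Against the amino group the same change gives a 5.6-fold higher number from compound 2 to compound 4 (0.75 log units; beyond the scatter), so among the four groups seen at this carbon, only the amino group of compound 2 stands apart, now with a sulfur-bearing group on the other side as well. No evidence is at hand that accounts for this result.

The compounds shown leave open whether the lower number belongs to the amino group alone or also comes with a methylamino group, a hydroxyl or a methoxy group at this carbon. They also leave open whether a longer thioether chain here would stay level with compound 4.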